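The compounds below may be only part of what the source reports. "The series", "measured", "known", "first", "only" and "open" are said of these compounds alone.

Measured so far in a functional assay on NCI-H460 cells (Homo sapiens) for inhibition, read by MTT assay, with a stated time of 24 h, tested at 0.1 ug/mL; a lower number here means less inhibition of growth, a higher number more inhibition of growth at the concentration tested:
- compound 1 `O=C(CCCCC(S)CCS)Nc1cccc(Cl)c1`: 9.78%
- compound 2 `O=C(CCCCC(S)CCS)Nc1cccc(C(F)(F)F)c1`: 12%

Only these two numbers are available for comparison. In this assay compound 2 gives 12% and sits level with compound 1, since the measured step is a number 2.2 percentage points higher from compound 1 to compound 2 (within the scatter).

Compound 3 `Cc1cccc(NC(=O)CCCCC(S)CCS)c1` has not yet been measured. It differs from compound 2 in one place: methyl in place of trifluoromethyl on an aromatic carbon. In words, this is methyl in place of trifluoromethyl on an aromatic carbon, and the rest of the molecule stays the same.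

For the measured compounds named here, one measured step bears on this change. It also swaps one group for another on an aromatic carbon, trifluoromethyl in place of chloro, and it amounts to a number 2.2 percentage points higher from compound 1 to compound 2 (within the scatter). The methyl group itself has not been measured on this core, so that single small step is thin evidence. It gives no direction, and no step beyond the scatter is expected.

For compound 3 the expected value is 11%, with an estimated range from 3% to 21%.

This estimate means an expected a number 1 percentage points lower from compound 2 to compound 3 (within the scatter).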

Compound 3, percent growth inhibition at one concentration: 9.34%
For compound 3 the middle estimate is 1.7 percentage points above the measured one; measured number inside the range.
By their numbers in this assay, from the lowest: compounds 3, 1 and 2 (each within the scatter of the next).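

In this assay, the swap at this place on the aromatic ring, meta to a large group, gives a number 2.7 percentage points lower from compound 2 to compound 3 (within the scatter) even though the group shrinks from 4 heavy atoms in trifluoromethyl to 1 heavy atom in methyl. For the compounds shown here, the third pairing, methyl against chloro, gives a number 0.4 percentage points lower from compound 1 to compound 3 (within the scatter) and so completes the picture: each of the three groups lies within the scatter of the other two, and no pair among them can be told apart at this position at the single concentration tested. With a carbon-only group now added to chloro and trifluoromethyl, this position shows no separation across a clear change in group size, and no measurement at hand offers an explanation for this flat result.

From the compounds shown here alone, whether any group at this place can move the number beyond the scatter remains open, for instance an amine, a carboxylic acid or a methoxy group. The compounds shown also leave open whether these same three groups would behave alike at other places on the ring, or at higher concentrations in this cell test.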